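Hydrogen in place of methoxy: the step to compound 3

The source may hold more compounds than are shown below. What is called first, only, known or untested is meant among the compounds shown, and "the series" means these compounds.

In a functional assay on the whole organism (strain Kunming) with Mus musculus as the target, in the formalin test, with a stated time of 0.5 h (a higher number here means that more compound is needed for the effect, a lower number that less compound is needed), compound 1 (`COc1cc(OC)c(OC)cc1/C=C/COC(=O)/C=C/c1ccc(OC)c(OC)c1`) gives 225 umol/kg. Compound 2 (`COc1cc(OC)c(OC)cc1/C=C/COC(=O)/C=C/c1cc(OC)c(OC)c(OC)c1OC`) gives 89 umol/kg, the lower of the two numbers, with a gap beyond the usual scatter. Compound 3 (`COc1cc(OC)c(OC)cc1/C=C/COC(=O)/C=C/c1ccc(OC)c(OC)c1OC`) has hydrogen in place of methoxy on an aromatic carbon of compound 2: hydrogen in place of methoxy on an aromatic carbon. Within the data shown here, no measured step isolates this change. Among the measured compounds shown here, the only guide is compound 1 at 225 umol/kg, which also lacks this methoxy. A modest rise in the number is therefore expected, possibly not beyond the scatter: a 1.6-fold higher number from compound 2 to compound 3 (0.20 log units; within the scatter). The estimated value for compound 3 is 140 umol/kg, with an expected range of 65 umol/kg to 290 umol/kg.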

Compound 3, dose for half-maximal effect: 176 umol/kg
Compound 3: middle estimate off by 1.3-fold (0.10 log units), on the low side; low and high end bracket the measured number.
By their numbers in this assay, from the lowest: compounds 2, 3 and 1 (each within the scatter of the next, the first and the last beyond it).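

In this assay, the series now has single-place changes on this aromatic ring, and hydrogen in place of methoxy gives a 2.0-fold higher number from compound 2 to compound 3 (0.30 log units; within the scatter). The other single change, methoxy in place of hydrogen on an aromatic carbon, gives a 1.3-fold lower number from compound 1 to compound 3 (0.11 log units; within the scatter), so neither change alone moves the number beyond the scatter. Nothing at hand gives a reason for either step.

Open, as far as these compounds go, is whether a hydroxy group, a fluorine atom or an amine on the aromatic carbon of the first step would give a step beyond the scatter. The compounds shown carry only methoxy or hydrogen there.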